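The compounds below may be only part of what the source reports. "The series", "measured", "known", "first", "only" and "open" are said of these compounds alone.

Series notes.
compound 1 `CN(Cc1ccc2nccn2c1)c1nnc(-c2ccc(-c3ccccc3)cc2)o1` gives 3.9 in a physicochemical assay for lipophilicity, at pH 7.4; on this read-out higher numbers stand for higher lipophilicity and lower numbers for lower lipophilicity
compound 2 `Cc1nn(C)c(C)c1-c1ccc(-c2nnc(N(C)Cc3ccc4nccn4c3)o2)c(F)c1` gives 3.2 in this assay
compound 3 `Cc1nn(C)c(C)c1-c1ccc(-c2nnc(N(C)Cc3ccc4nccn4c3)o2)c(Cl)c1` gives 3.3 in this assay

On these three numbers compound 3 stands second highest: its nearest neighbour is compound 2, within the scatter, and its furthest is compound 1, beyond the scatter. Compound 4 `Cc1nn(C)c(C)c1-c1ccc(-c2nnc(N(C)Cc3ccc4nccn4c3)o2)c(C#N)c1` has not yet been measured. The change from compound 3 is cyano in place of chloro on an aromatic carbon. Within the data shown here, only one measured step bears on the same place, a number 0.10 log units higher from compound 2 to compound 3 (within the scatter), a step within the scatter; no measured step exchanges chloro for cyano, so there is no direct precedent. A downward step beyond the scatter, a number 1.00 log units lower from compound 3 to compound 4 (beyond the scatter), is expected here. Compound 4 is therefore estimated at 2.3, with a range from 1.8 to 2.8.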

Compound 4, distribution coefficient: 2.9
Estimate against measurement, compound 4: 0.60 log units below, outside the stated range (above it).
By their numbers in this assay, from the lowest: compounds 4, 2 and 3 (each within the scatter of the next, the first and the last beyond it); then compound 1.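

Among these compounds, at this place on the ring, in this assay, cyano in place of chloro gives the first step beyond the scatter (a number 0.40 log units lower from compound 3 to compound 4 (beyond the scatter)), while chloro in place of fluoro had stayed within it (a number 0.10 log units higher from compound 2 to compound 3 (within the scatter)). Cyano in place of fluoro remains within the scatter (a number 0.30 log units lower from compound 2 to compound 4 (within the scatter)), so among these three substituents only the chloro and cyano pair is separated. No measurement on hand accounts for this step.

Still open, as far as these compounds go, is whether a methoxy group or an amine at this place would fall with cyano or with chloro and fluoro. Also open, from the compounds shown here alone, is whether the cyano step holds on the core of compound 1.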